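Morpholine amide in place of the acid on the alanine arm

The source may report more compounds than this note shows. Statements on the series, on what has been measured and on what is new or still open speak of the compounds shown alone.

Compound 1 `C[C@@H](C(=O)O)N1C(=O)/C(=C/c2ccc(Br)cc2)SC1=S` carries a carboxylic acid on the chain that leaves the ring nitrogen. Within the data shown here, in an assay on isolated protein for displacement of a labelled ligand from Apoptosis regulator Bcl-2 (Homo sapiens), read by fluorescence polarization (a higher number here means a weaker inhibitor, a lower number a stronger inhibitor), compound 1 gives 115000 nM, the higher of the two numbers measured so far. Among the measured compounds shown here, its one neighbour is compound 2 `CC(C)C[C@@H](C(=O)O)N1C(=O)/C(=C/c2ccc(Br)cc2)SC1=S`, which in this assay gives 7430 nM; the step of a 15-fold lower number from compound 1 to compound 2 (1.19 log units; beyond the scatter) is the only one the series holds. Compound 3 `C[C@@H](C(=O)N1CCOCC1)N1C(=O)/C(=C/c2ccc(Br)cc2)SC1=S` is not yet measured. The change from compound 1 to compound 3 is morpholin-4-yl in place of hydroxy on a carbonyl carbon.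

For the measured compounds named here, no measured step touches the carbonyl carbon of the acid: the step from compound 1 to compound 2 sits on the chain carbon and says nothing about what the acid itself contributes. The expectation for compound 3 therefore rests on the bare fact that compound 1 is already a weak inhibitor and on the size of the change. A step of a 1.0-fold higher number from compound 1 to compound 3 (0.02 log units; within the scatter) is expected, with the direction left open and the range wide. Compound 3 is estimated at 120000 nM in this assay, between 25000 nM and 600000 nM.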

Compound 3, inhibition constant: 70000 nM
For compound 3 the middle estimate is 1.7-fold (0.23 log units) above the measured one; low and high end bracket the measured number.
By their numbers in this assay, from the lowest: compound 2; then compounds 3 and 1 (each within the scatter of the next).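

In this assay, among these compounds, morpholin-4-yl in place of hydroxy on a carbonyl carbon gives a 1.6-fold lower number from compound 1 to compound 3 (0.22 log units; within the scatter), the first reading at this position. Among the compounds shown here, the carboxylic acid of compound 1 can therefore be exchanged for a (morpholin-4-yl)carbonyl group, which adds a six-membered ring and removes the hydrogen-bond donor of the hydroxy, with no shift beyond the scatter; in this pair, the hydroxy is not needed to keep the number at this level, while the only step beyond the scatter remains a 15-fold lower number from compound 1 to compound 2 (1.19 log units; beyond the scatter), made on the chain carbon. The data offer no explanation for the two numbers lying so close, so the result stands as an observation only.

Open, from the compounds shown here alone, is whether the same tolerance holds with the isopropyl substituent of compound 2 on the chain carbon, that is, whether a morpholine amide on that chain would keep the number of compound 2 or lose it. Also open, going by these compounds, is how far this position accepts other groups, such as a piperidine amide, a primary amide or a methyl ester, since a single amide cannot show whether the tolerance extends beyond morpholine.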